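The source may report more compounds than this note shows. Statements on the series, on what has been measured and on what is new or still open speak of the compounds shown alone.

In a functional assay on B16-F10 cells (Mus musculus) for antiproliferative activity, read by CCK-8 assay, with a stated time of 48 h (a lower number here means a stronger inhibitor, a higher number a weaker inhibitor), compound 1 `COc1ccc(/C=C\c2cc(OC)c(OC)c(OC)c2)cc1OCc1ccc(C=O)cc1`, which carries a formyl group, gives 4200 nM. Compound 2 `COc1ccc(/C=C\c2cc(OC)c(OC)c(OC)c2)cc1OCc1ccc(CN2CCCCC2C(=O)O)cc1` reaches only a limit of the assay, > 10000 nM. Compound 3 `COc1ccc(/C=C\c2cc(OC)c(OC)c(OC)c2)cc1OCc1ccc(CN[C@H](C(=O)O)[C@H](C)O)cc1` also stands only at a limit, > 10000 nM, the same one the limit of > 10000 nM in this assay, at which 2 of the 3 values shown sit, as compound 2, so no number places it. Compound 4 `COc1ccc(/C=C\c2cc(OC)c(OC)c(OC)c2)cc1OCc1ccc(CN2CC(C(=O)O)C2)cc1` exchanges one carboxy-bearing group for another: 3-carboxyazetidin-1-yl in place of (1-carboxy-2-hydroxypropyl)amino on a saturated chain carbon bound to an aromatic carbon. Replacing formyl with such a group gave an at least 2.3-fold higher number from compound 1 to compound 2 (0.37 log units; beyond the scatter) and an at least 2.3-fold higher number from compound 1 to compound 3 (0.37 log units; beyond the scatter), both toward weaker inhibition. Going by the values given here, the closest precedent, exchanging one such group for another, gave a step that the two limits leave unreadable from compound 2 to compound 3. A result near the limit therefore seems likely. The expected step is a step that the limit leaves unreadable from compound 3 to compound 4, with no clear change anticipated. For compound 4 the estimated value is 12000 nM, within an expected range of 5000 nM to 30000 nM.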

Compound 4, half-maximal inhibitory concentration: > 10000 nM
Compound 4: no number, only a limit; the forecaster's own chance of this, stated with the estimate: 70%; the middle value lies beyond the limit too.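

With (3-carboxyazetidin-1-yl)methyl in place of formyl on an aromatic carbon, this assay shows an at least 2.3-fold higher number from compound 1 to compound 4 (0.37 log units; beyond the scatter), so a group with a four-membered ring joins the open-chain and six-membered carboxy-bearing groups in falling short of compound 1. The steps among compound 2, compound 3 and compound 4 cannot be read, so these groups cannot be ranked. The value of compound 4 is only a limit: the limit of > 10000 nM in this assay, at which 3 of the 4 values shown sit.

The compounds shown leave open whether the carboxylic acid itself goes with the weaker inhibition. A plain azetidine or piperidine amine, or a methyl ester of the acid, on the same saturated chain carbon would address that.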